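Adding a Hydroxy Group to an Inactive Core

The source may report more compounds than this note shows. Statements on the series, on what has been measured and on what is new or still open speak of the compounds shown alone.

Compound 2 `C[C@@H]1C(=O)[C@H]2C[C@]1(O)CC1=C2[C@]2(C)CCCC(C)(C)[C@H]2CC1` was tested in a functional assay on SK-OV-3 cells (Homo sapiens) for cytotoxicity, read by MTT assay, with a stated time of 24 h; a higher number here means a weaker inhibitor, a lower number a stronger inhibitor. In this assay compound 2 gives > 50000 nM, which is a limit of the assay and not a number. Compound 1 `C[C@@H]1C(=O)[C@H]2C[C@]1(O)CC1=C2[C@]2(C)CCC[C@](C)(CO)[C@H]2CC1` carries a hydroxy on a saturated chain carbon bound to a saturated ring carbon, and in this assay compound 1 gives > 50000 nM, again a limit. The step that the two limits leave unreadable from compound 1 to compound 2 therefore cannot be read, and the limit of > 50000 nM in this assay, at which 2 of the 2 values shown sit, is all that the two values show. Compound 3 `C[C@@H]1C(=O)[C@H]2C[C@]1(O)CC1=C2[C@]2(C)CCC[C@@](C)(CO)[C@H]2CC1` differs from compound 2 by hydroxy in place of hydrogen on a saturated chain carbon bound to a saturated ring carbon. For the measured compounds named here, no measured step bears on this change in a readable way, so no step beyond the scatter can be expected in either direction in this assay. Compound 3 is therefore expected to give 80000 nM, within 40000 nM to 200000 nM, most likely again reported only as a limit. The step that the limit leaves unreadable from compound 2 to compound 3 is the expected outcome of this change.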

Compound 3, half-maximal inhibitory concentration: > 50000 nM
Compound 3: no number, only a limit; the forecaster's own chance of this, stated with the estimate: 85%; the middle value is on the limit's open side.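

In this assay compound 3 gives > 50000 nM, a limit of the assay and not a number. For the compounds shown here, no step joining compound 3 to compound 1 or compound 2 can be read. Whether the hydroxy, or the configuration that separates compound 1 from compound 3, changes cytotoxicity at all stays open: the limit of > 50000 nM in this assay, at which 3 of the 3 values shown sit.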